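The source may report more compounds than this note shows. Statements on the series, on what has been measured and on what is new or still open speak of the compounds shown alone.

Measured so far:
Compound 1, `CCS[C@@H]1[C@H](SCC)[C@@H](Cn2cc(-c3ccc(F)cc3)nn2)O[C@H]1n1ccc(=O)[nH]c1=O`, gives 72400 nM
Compound 2, `CCS[C@@H]1[C@H](SCC)[C@@H](Cn2cc(-c3cccc(C)c3)nn2)O[C@H]1n1ccc(=O)[nH]c1=O`, gives 99000 nM

Both compounds share one core and differ only in the aromatic group that hangs from the five-membered ring with three nitrogens. In a functional assay on LAC cells (Homo sapiens) for cytotoxicity, read by MTT assay, with a stated time of 72 h (on this read-out lower numbers stand for an effect already at smaller amounts and higher numbers for an effect only at larger amounts of compound), compound 1 gives 72400 nM and compound 2 gives 99000 nM. Going by the values given here, the one measured step, a 1.4-fold higher number from compound 1 to compound 2 (0.14 log units; within the scatter), shows that swapping one six-membered aromatic group for another left the read-out essentially unchanged. Compound 2 therefore stands with compound 1 inside the same band of scatter; neither can be called stronger or weaker than the other on these two numbers.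

Compound 3, `CCS[C@@H]1[C@H](SCC)[C@@H](Cn2cc(-c3cccs3)nn2)O[C@H]1n1ccc(=O)[nH]c1=O`, takes the change (thiophen-2-yl in place of 3-methylphenyl on an aromatic carbon). Among the compounds with values here, only the step from compound 1 to compound 2 bears on this, and that step was within the scatter; there is no measured example of a five-membered aromatic group at this place. With nothing pointing to a move in either direction, the expectation is no step beyond the scatter, a 1.2-fold lower number from compound 2 to compound 3 (0.07 log units; within the scatter). Compound 3 is thus estimated at 85000 nM, with a likely range from 30000 nM to 250000 nM.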

Compound 3, half-maximal effective concentration: 86500 nM
The estimate for compound 3 lay 1.0-fold (0.01 log units) below the measured number; measured number inside the range.
By their numbers in this assay, from the lowest: compounds 1, 3 and 2 (each within the scatter of the next).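

The new compound brings a different kind of ring to this place, on an aromatic carbon of the five-membered aromatic ring with 3 nitrogen: thiophen-2-yl is a five-membered aromatic ring with 1 hetero atom, whereas the earlier groups were six-membered rings of carbon only. In this assay, the swap from 3-methylphenyl to thiophen-2-yl gives a 1.1-fold lower number from compound 2 to compound 3 (0.06 log units; within the scatter), and the swap from 4-fluorophenyl to thiophen-2-yl gives a 1.2-fold higher number from compound 1 to compound 3 (0.08 log units; within the scatter). Both steps lie within the scatter, so this read-out does not separate the three groups, even though thiophen-2-yl has 5 heavy atoms and 1 hydrogen-bond acceptor while 3-methylphenyl has 7 heavy atoms and no hydrogen-bond acceptor.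

On these data alone, all three groups at this place are aromatic rings, so it remains open whether an amine, a carboxylic acid or a longer alkyl chain there would shift the number beyond the scatter. As far as these compounds go, it also remains open whether a change elsewhere in the shared core would move the read-out. Nothing in the available information explains why these three groups cannot be told apart.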